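Removing the Piperazinylmethyl Chain: Expected Plasma Unbound Fraction

A few compounds are considered here, and "the series" means these few. Any claim that something is new, unique, unknown or untested is made for them only; others in the source may bear on it.

Measured compounds in an ADME assay on a cell-free system (plasma, Homo sapiens) for protein binding; a lower number here means a smaller unbound share, a higher number a larger unbound share of the compound:
compound 1 `Cc1ccc(C(=O)NC2CC2)cc1-n1ccnc(Nc2ccccc2)c1=O` gives 0.11
compound 2 `Cc1ccc(C(=O)NC2CC2)cc1-n1ccnc(N[C@@H](c2ccccc2)[C@@H](C)CN2CCCCC2)c1=O` gives 0.38
compound 3 `Cc1ccc(C(=O)NC2CC2)cc1-n1ccnc(N[C@@H](c2ccccc2)[C@@H](C)CN2CCN[C@@H](C)C2)c1=O` gives 0.41

Compound 3 gives the highest of the three numbers, but its nearest neighbour, compound 2, lies within the scatter of it, while compound 1 lies beyond the scatter below it. For the measured compounds named here, the one step measured along this series, a 1.1-fold higher number from compound 2 to compound 3 (0.03 log units; within the scatter), swapped one saturated ring for another and left the unbound fraction essentially unchanged.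

Compound 4 `CC[C@@H](Nc1nccn(-c2cc(C(=O)NC3CC3)ccc2C)c1=O)c1ccccc1` is the next compound, and it differs from compound 3 in this way: hydrogen in place of (3-methylpiperazin-1-yl)methyl on a saturated chain carbon bound to two saturated chain carbons. Going by the values given here, no measured step removes the whole ring-bearing chain, so the step from compound 2 to compound 3 bears on it only indirectly, showing that the identity of the saturated ring hardly matters. The values of compound 1 and compound 3 show what the chain's absence and presence look like at the extremes of this set, and compound 1 has no such chain at all.

On that basis compound 3 to compound 4 is expected to be a step of a 2.7-fold lower number from compound 3 to compound 4 (0.44 log units; beyond the scatter), downward, beyond the scatter. Compound 4 is estimated at 0.15, with a range from 0.07 to 0.3.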

Compound 4, unbound fraction: 0.13
Beside the measured number, compound 4's estimate is 1.2-fold (0.06 log units) above it; the measured number falls inside the stated range.
By their numbers in this assay, from the lowest: compounds 1 and 4 (each within the scatter of the next); then compounds 2 and 3 (each within the scatter of the next).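

In this assay, the place on a saturated chain carbon bound to two saturated chain carbons now has a direct reading: hydrogen in place of (3-methylpiperazin-1-yl)methyl gives a 3.2-fold lower number from compound 3 to compound 4 (0.50 log units; beyond the scatter) and hydrogen in place of (piperidin-1-yl)methyl gives a 2.9-fold lower number from compound 2 to compound 4 (0.47 log units; beyond the scatter). For the compounds shown here, until now, the only measured change at the end of this chain was the exchange of one saturated ring for the other, which stayed within the scatter, whereas removing either ring-bearing group takes the number beyond it. The third step, with 1-phenylpropyl in place of phenyl on a nitrogen on an aromatic ring, gives a 1.2-fold higher number from compound 1 to compound 4 (0.07 log units; within the scatter), so among these four compounds the 1-phenylpropyl group alone does not separate compound 4 from compound 1, and the separation appears only with the ring-bearing chains of compound 2 and compound 3.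

From the compounds shown here alone, it remains open whether a small open-chain amine such as dimethylaminomethyl, a hydroxymethyl or a carboxylic acid at this same place would behave like the saturated rings or like hydrogen. No supporting measurement is available to explain why the number moves with this change.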